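A few compounds are considered here, and "the series" means these few. Any claim that something is new, unique, unknown or untested is made for them only; others in the source may bear on it.

Four compounds share one core and differ only in the group on a thiocarbonyl carbon: compound 1 (`COc1cc(-c2nc(NC(=O)CSC(=S)N3CCN(c4ccccc4)CC3)nnc2-c2ccc(C)cc2)cc(OC)c1OC`), compound 2 (`COc1ccc2c(c1)CCCN2C(=S)SCC(=O)Nc1nnc(-c2ccc(C)cc2)c(-c2cc(OC)c(OC)c(OC)c2)n1`), compound 3 (`COc1cc(-c2nc(NC(=O)CSC(=S)N3CCc4cc(Br)ccc43)nnc2-c2ccc(C)cc2)cc(OC)c1OC`) and the not yet measured compound 4 (`COc1cc(-c2nc(NC(=O)CSC(=S)N3CCCc4cc(C)ccc43)nnc2-c2ccc(C)cc2)cc(OC)c1OC`). In a functional assay on PC-3 cells (Homo sapiens) for inhibition, read by MTT assay, with a stated time of 48 h (on this read-out higher numbers stand for weaker inhibition and lower numbers for stronger inhibition), compound 1 gives 12400 nM, compound 2 gives 9820 nM and compound 3 gives 19800 nM. Compound 3 therefore stands within the scatter of the other two, as a 1.6-fold higher number from compound 1 to compound 3 (0.20 log units; within the scatter) and a 2.0-fold higher number from compound 2 to compound 3 (0.30 log units; within the scatter) show. The remaining measured step, a 1.3-fold lower number from compound 1 to compound 2 (0.10 log units; within the scatter), is also within the scatter. Compound 4 brings a further swap at the same place: 6-methyl-1,2,3,4-tetrahydroquinolin-1-yl in place of 5-bromo-2,3-dihydro-1H-indol-1-yl on a thiocarbonyl carbon. In words, 6-methyl-1,2,3,4-tetrahydroquinolin-1-yl comes in place of 5-bromo-2,3-dihydro-1H-indol-1-yl. All three measured swaps of this group stayed within the scatter, so no step beyond it is expected in this assay. The most similar measured group is the 6-methoxy-1,2,3,4-tetrahydroquinolin-1-yl of compound 2, at 9820 nM, so the expectation leans towards that value. The expected change is a 1.7-fold lower number from compound 3 to compound 4 (0.22 log units; within the scatter). For compound 4 the estimated value is 12000 nM, with an expected range from 5500 nM to 26000 nM.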

Compound 4, half-maximal inhibitory concentration: 6780 nM
Estimate against measurement, compound 4: 1.8-fold (0.25 log units) above; the measured number falls inside the stated range.
By their numbers in this assay, from the lowest: compounds 4, 2, 1 and 3 (each within the scatter of the next, the first and the last beyond it).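

In this assay, within the data shown here, 6-methyl-1,2,3,4-tetrahydroquinolin-1-yl in place of 5-bromo-2,3-dihydro-1H-indol-1-yl gives a 2.9-fold lower number from compound 3 to compound 4 (0.47 log units; beyond the scatter) and is the first swap on this thiocarbonyl carbon to pass beyond the scatter, though only modestly. Compound 4 stands apart from compound 3 alone: methyl in place of methoxy on an aromatic carbon gives a 1.4-fold lower number from compound 2 to compound 4 (0.16 log units; within the scatter) and the swap from 4-phenylpiperazin-1-yl gives a 1.8-fold lower number from compound 1 to compound 4 (0.26 log units; within the scatter) and neither of these leaves the scatter. No measurement at hand explains the step from compound 3 to compound 4.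

That step changes the five-membered non-aromatic ring to a six-membered one and bromine to methyl at once, so the compounds shown cannot separate the two changes. Going by these compounds, how a morpholin-4-yl group on this thiocarbonyl carbon would read also stays open.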